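The compounds below may be only part of what the source reports. "The series", "measured", "known", "first", "only" and "open" are said of these compounds alone.

Measured compounds:
Compound 1, `COc1ccc(C(=O)/C=C/c2cc(OC)c(OC)cc2OC)cc1`, in a functional assay on SW982 cells (Homo sapiens) for inhibition, read by MTT assay, with a stated time of 72 h (a higher number here means a weaker inhibitor, a lower number a stronger inhibitor), gives 60500 nM.
Compound 2, `COc1cc(OC)c(OC)cc1/C=C/C(=O)c1ccc(O)cc1O`, in this assay gives 32400 nM.

For the measured compounds named here, compound 2 holds the lowest of the two numbers so far, but its only neighbour is compound 1, and the step of a 1.9-fold lower number from compound 1 to compound 2 (0.27 log units; within the scatter) is within the scatter, so the two cannot be told apart on these data. The next compound, compound 3, `COc1cc(OC)c(OC)cc1/C=C/C(=O)c1cc(Cl)ccc1O`, is not yet measured. It differs from compound 2 in one place: 5-chloro-2-hydroxyphenyl in place of 2,4-dihydroxyphenyl on a carbonyl carbon.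

Going by the values given here, the only measured step, a 1.9-fold lower number from compound 1 to compound 2 (0.27 log units; within the scatter), changes the same ring on the carbonyl carbon, but exchanges a different pair of groups, so it bears on compound 3 only loosely. It shows that an exchange at this place moved the number by no more than the scatter. Nothing measured speaks to the 5-chloro-2-hydroxyphenyl group itself. On that basis no step beyond the scatter is expected in this assay for compound 3, and the step of a 1.1-fold lower number from compound 2 to compound 3 (0.03 log units; within the scatter) is expected to stay within it. Compound 3 is therefore estimated at 30000 nM, with a range from 10000 nM to 90000 nM.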

Compound 3, half-maximal inhibitory concentration: > 150000 nM
Compound 3: no number, only a limit; the forecaster's own chance of this, stated with the estimate: 20%; at least 5.0-fold (0.69 log units) between middle value and limit.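

Compound 3 carries no number in this assay, only a limit of the assay: the limit of > 150000 nM in this assay, at which 1 of the 3 values shown sits. Even so, this is the first exchange on the ring at the carbonyl carbon to pass the scatter, giving an at least 4.6-fold higher number from compound 2 to compound 3 (0.66 log units; beyond the scatter), and the 5-chloro-2-hydroxyphenyl group also separates from the 4-methoxyphenyl group, with an at least 2.4-fold higher number from compound 1 to compound 3 (0.39 log units; beyond the scatter). The earlier step, a 1.9-fold lower number from compound 1 to compound 2 (0.27 log units; within the scatter), had left this place looking indifferent to the exchange, whereas the three compounds now show that the group held on the carbonyl carbon can matter in this assay, and that 5-chloro-2-hydroxyphenyl is the unfavourable one among those shown.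

The compounds shown do not separate the two parts of the last exchange, the chlorine that enters and the oxygen that leaves, so neither part can be held responsible for the step on its own, and the full size of the step stays unknown behind the limit. Going by these compounds, how an amine or a carboxylic acid on this ring would read in this assay also stays open.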